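Swapping the amide for an ethyl ester on the side chain

The source may hold more compounds than are shown below. What is called first, only, known or untested is meant among the compounds shown, and "the series" means these compounds.

Among the measured compounds shown here, compound 2 `CNC(=O)NC[C@H]1O[C@@H](n2cnc3c(NC(=O)Nc4ccccc4)ncnc32)[C@H](O[Si](C)(C)C(C)(C)C)[C@@H]1CC(=O)N(C)OC` is one of two compounds measured in a functional assay on RXF 393 cells (Homo sapiens) for antiproliferative activity (on this read-out lower numbers stand for stronger inhibition of growth and higher numbers for weaker inhibition of growth), and among them compound 2 gives the higher number, 9.74 nM. Its nearest neighbour, compound 1 `CCOC(=O)C[C@H]1[C@@H](O[Si](C)(C)C(C)(C)C)[C@H](n2cnc3c(NC(=O)Nc4ccccc4)ncnc32)O[C@@H]1COC(=O)NC`, gives 2.94 nM in this assay, a gap beyond the usual scatter. Compound 3 `CCOC(=O)C[C@H]1[C@@H](O[Si](C)(C)C(C)(C)C)[C@H](n2cnc3c(NC(=O)Nc4ccccc4)ncnc32)O[C@@H]1CNC(=O)NC` has not yet been measured. Relative to compound 2 it differs by ethoxy in place of methoxy(methyl)amino on a carbonyl carbon. Because compound 1, which also carries the ethoxy group, gives 2.94 nM, compound 3 is expected to move toward lower numbers, with a modest step of a 1.9-fold lower number from compound 2 to compound 3 (0.29 log units; within the scatter). Compound 3 is estimated at 5 nM, between 2 nM and 12 nM.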

Compound 3, concentration for 50% growth inhibition: 2.01 nM
The estimate for compound 3 lay 2.5-fold (0.40 log units) above the measured number; low and high end bracket the measured number.
By their numbers in this assay, from the lowest: compounds 3 and 1 (each within the scatter of the next); then compound 2.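

In this assay, among the compounds shown here, ethoxy in place of methoxy(methyl)amino on a carbonyl carbon gives a 4.8-fold lower number from compound 2 to compound 3 (0.69 log units; beyond the scatter) as the first reading of this change on its own. The other single-place change, (methylcarbamoyl)amino in place of (methylcarbamoyl)oxy on a saturated chain carbon bound to a saturated ring carbon, gives a 1.5-fold lower number from compound 1 to compound 3 (0.17 log units; within the scatter) and does not separate the two compounds. No measurement here offers a reason for either step. On these data alone, whether a carboxylic acid or a longer chain on that carbonyl carbon would keep numbers at this level remains open.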